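Loss of the (cyanomethyl)carbonyl group, compound 3 to compound 4

The source may report more compounds than this note shows. Statements on the series, on what has been measured and on what is new or still open speak of the compounds shown alone.

The series is read in a functional assay on SMMC-7721 cells (Homo sapiens) for inhibition, read by MTT assay; a higher number here means a weaker inhibitor, a lower number a stronger inhibitor. Compound 2 `N#CCC(=O)Nc1sc(C(=O)Nc2ccc(Cl)cc2)c(-c2ccccc2)c1C#N` gives 390 nM. Compound 1 `N#Cc1c(N)sc(C(=O)Nc2ccc(Cl)cc2)c1-c1ccccc1` differs from compound 2 by hydrogen in place of (cyanomethyl)carbonyl on a nitrogen on an aromatic ring. In this assay compound 1 gives 690 nM; the step is a 1.8-fold higher number from compound 2 to compound 1 (0.25 log units; within the scatter), so the two numbers lie within the scatter of each other and no direction can be read from this pair alone.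

Compound 3 `CCOC(=O)c1c(NC(=O)CC#N)sc(C(=O)Nc2ccccc2)c1-c1ccccc1` gives 530 nM in this assay. The difference between the core of compound 3 and the core of compound 2 is not broken down here. For the measured compounds named here, compound 4 `CCOC(=O)c1c(N)sc(C(=O)Nc2ccccc2)c1-c1ccccc1` is not yet measured; it differs from compound 3 by hydrogen in place of (cyanomethyl)carbonyl on a nitrogen on an aromatic ring, the same change as the one from compound 2 to compound 1, at a place described in the same words.

Going by the values given here, the expected step of a 1.6-fold higher number from compound 3 to compound 4 (0.21 log units; within the scatter) is taken to be of the same size as the measured one, because a 1.8-fold higher number from compound 2 to compound 1 (0.25 log units; within the scatter) is the only precedent for the change and shows a small shift. On that basis compound 4 is estimated at 850 nM in this assay, with a range of 400 nM to 1800 nM.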

Compound 4, half-maximal inhibitory concentration: 8580 nM
Estimate against measurement, compound 4: 10-fold (1.00 log units) below; the whole stated range lies below it.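

In this assay, replacing (cyanomethyl)carbonyl with hydrogen on the nitrogen gives a 16-fold higher number from compound 3 to compound 4 (1.21 log units; beyond the scatter), so the change does not carry over at one size between these two cores: the same change on two cores in this assay, a 1.8-fold higher number (0.25 log units; within the scatter) from compound 2 to compound 1 and a 16-fold higher number (1.21 log units; beyond the scatter) from compound 3 to compound 4, 9.2-fold (0.96 log units) apart, beyond the scatter of two such steps. Across the two pairs, a step measured on one core is therefore a poor guide to the step on the other, and the (cyanomethyl)carbonyl group matters far more on the core of compound 3 than any shift that can be read on the core of compound 2. This does not show which feature sets the size of the step, as the core of compound 2 and the core of compound 3 differ in more than one place, and two pairs support no general rule for the series.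

Still open, going by these compounds, is whether the nitrile in place of the ethyl ester, or the chlorine, accounts for the gap between the two steps when either is changed alone. Also open, on these data alone, is whether a simple acetyl group on the same nitrogen would behave as (cyanomethyl)carbonyl does on each core.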